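Chloro to trifluoromethyl on the benzamide of compound 3

The source may hold more compounds than are shown below. What is called first, only, known or untested is meant among the compounds shown, and "the series" means these compounds.

Compound 3 `O=C(Nc1ccc(-n2cc(-c3ccncc3)c(-c3ccc(Cl)c(O)c3)n2)cc1)c1ccc(Cl)c(Cl)c1` gives 6700 nM in a functional assay on A375P cells (Homo sapiens) for antiproliferative activity, read by MTT assay, with a stated time of 48 h (a lower number here means a stronger inhibitor, a higher number a weaker inhibitor), the lowest of the three numbers in hand. Compound 1 `COc1cc(-c2nn(-c3ccc(NC(=O)c4ccc(Cl)c(C(F)(F)F)c4)cc3)cc2-c2ccncc2)ccc1Cl`, which carries the same benzamide but a methoxy in place of the phenol, gives 9800 nM; compound 2 `O=C(Nc1ccc(-n2cc(-c3ccncc3)c(-c3ccc(Cl)c(O)c3)n2)cc1)Nc1ccc(Cl)c(C(F)(F)F)c1`, the urea, gives 14900 nM. Among the compounds with values here, the only single-point step measured is a 2.2-fold lower number from compound 2 to compound 3 (0.35 log units; beyond the scatter), and it changes the carbonyl linkage together with the aryl substituent, so it bears on the present change only in part.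

Compound 4 `O=C(Nc1ccc(-n2cc(-c3ccncc3)c(-c3ccc(Cl)c(O)c3)n2)cc1)c1ccc(Cl)c(C(F)(F)F)c1` differs from compound 3 by trifluoromethyl in place of chloro on an aromatic carbon. The pair compound 1 and compound 3 differs elsewhere, yet their values stand within the scatter of each other and show that this benzamide pattern gives numbers in the same region as the dichloro one. Within the data shown here, no measured step isolates the chloro-to-trifluoromethyl exchange itself, so no direction is established.

The expected step is therefore a 1.2-fold higher number from compound 3 to compound 4 (0.08 log units; within the scatter), within the scatter. Compound 4 is estimated at 8000 nM, with a range from 4000 nM to 16000 nM.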

Compound 4, half-maximal inhibitory concentration: 6800 nM
Estimate against measurement, compound 4: 1.2-fold (0.07 log units) above; the measured number falls inside the stated range.
By their numbers in this assay, from the lowest: compounds 3, 4, 1 and 2 (each within the scatter of the next, the first and the last beyond it).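

Within this assay, the exchange on this aromatic carbon is now isolated: a 1.0-fold higher number from compound 3 to compound 4 (0.01 log units; within the scatter), so at this position trifluoromethyl, with 4 heavy atoms, and chloro, with 1, cannot be told apart. With the 4-chloro-3-(trifluoromethyl)phenyl group held constant, the amide-for-urea change alone gives a 2.2-fold lower number from compound 2 to compound 4 (0.34 log units; beyond the scatter), a modest step that involves no change at the chloro position and matches the size of a 2.2-fold lower number from compound 2 to compound 3 (0.35 log units; beyond the scatter). On the other ring, the phenol and its methyl ether also cannot be told apart, with a 1.4-fold lower number from compound 1 to compound 4 (0.16 log units; within the scatter).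

On these data alone, whether an amine, a carboxylic acid or a nitrile on this aromatic carbon would break from the chloro and trifluoromethyl results stays open. Nothing available explains the size of any of these steps.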